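Epimer at the ring hydroxyl carbon: notes on compound 4

A few compounds are considered here, and "the series" means these few. Any claim that something is new, unique, unknown or untested is made for them only; others in the source may bear on it.

Measured compounds in a functional assay on HeLa cells (Homo sapiens) for antiproliferative activity, read by sulforhodamine B assay; a higher number here means a weaker inhibitor of growth, a lower number a stronger inhibitor of growth:
- compound 1, `CC[C@@H]1O[C@H](COCc2ccccc2)[C@@H](OCc2ccccc2)[C@H](OCc2ccccc2)[C@H]1O`: 19800 nM
- compound 2, `CC[C@@H]1O[C@H](COCc2ccccc2)[C@@H](OCc2ccccc2)[C@H](OCc2ccccc2)[C@H]1OC(C)=O`: reported only as a limit, > 50000 nM
- compound 3, `CCC[C@@H]1O[C@H](COCc2ccccc2)[C@@H](OCc2ccccc2)[C@H](OCc2ccccc2)[C@H]1O`: 18900 nM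

Compound 3 gives the lowest number of the two numeric values, and its nearest neighbour is compound 1; the step of a 1.0-fold lower number from compound 1 to compound 3 (0.02 log units; within the scatter) sits within the scatter, so the two are not distinguishable. Compound 2 carries the acetyl on the ring oxygen and is one of the values sitting at the limit of > 50000 nM in this assay, at which 1 of the 3 values shown sits; the step of an at least 2.5-fold higher number from compound 1 to compound 2 (0.40 log units; beyond the scatter) is at least modest, so a free hydroxyl on that ring carbon appears to matter here.

Compound 4, `CCC[C@@H]1O[C@H](COCc2ccccc2)[C@@H](OCc2ccccc2)[C@H](OCc2ccccc2)[C@@H]1O`, is the epimer of compound 3: the two compounds have the same atoms and bonds and differ only in configuration as drawn: 1 of 5 stereo elements differ; a stereocentre at a saturated ring carbon is drawn S in compound 3 and R in compound 4. Among the measured compounds shown here, no measured step changes a configuration, so no step bears on this change directly. The free hydroxyl is retained, which is the feature whose loss in compound 2 cost activity. The expected step of a 1.4-fold higher number from compound 3 to compound 4 (0.14 log units; within the scatter) is therefore small, with a lean toward a weaker result and a real chance that the assay reports only a limit. The estimate for compound 4 in this assay is 26000 nM, in the range 9000 nM to 70000 nM.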

Compound 4, concentration for 50% growth inhibition: 23300 nM
Compound 4: the middle estimate sits 1.1-fold (0.05 log units) above what was measured, and the stated range covers the measured number.
By their numbers in this assay, from the lowest: compounds 3, 1 and 4 (each within the scatter of the next). At a limit, above all of these: compound 2.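

In this assay, among the compounds shown here, inverting the ring hydroxyl carbon gives a 1.2-fold higher number from compound 3 to compound 4 (0.09 log units; within the scatter), the first direct reading of configuration at this position, and the change stays within the scatter. The comparison isolates this one stereocentre: the fact that compounds 3 and 4 differ only in the configuration as drawn. For the compounds shown here, with the hydroxyl free, either drawn configuration at this carbon is therefore compatible with the same read-out, while the acetyl step an at least 2.5-fold higher number from compound 1 to compound 2 (0.40 log units; beyond the scatter) remains the only change beyond the scatter, and that step rests on a limit.

As far as these compounds go, it remains open whether an acetyl on the hydroxyl of compound 4 would have the same consequence as on compound 1. Going by these compounds alone, also open is whether configuration at this carbon stays without a readable effect when an amine replaces the hydroxyl or a longer chain replaces the one in compound 3.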